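Working notes: chloro in place of hydroxy on compound 1

A few compounds are considered here, and "the series" means these few. Any claim that something is new, unique, unknown or untested is made for them only; others in the source may bear on it.

Measured in a functional assay on SK-BR-3 cells (Homo sapiens) for antiproliferative activity, with a stated time of 48 h; on this read-out lower numbers stand for an effect already at smaller amounts and higher numbers for an effect only at larger amounts of compound:
- compound 1 `O=C(CCCCCCC(=O)Nc1ccc(O)cc1)NO` gives 11000 nM
- compound 2 `O=C(CCCCCCC(=O)Nc1cccc(F)c1)NO` gives 1900 nM

Of the two measured compounds, compound 1 stands highest at 11000 nM, and compound 2 gives a lower number at 1900 nM, a gap beyond the usual scatter. Within the data shown here, these two differ in more than one place, so no single-place step is available as a guide.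

Compound 3 `O=C(CCCCCCC(=O)Nc1ccc(Cl)cc1)NO` differs from compound 1 at one place, with chloro in place of hydroxy on an aromatic carbon, para to a large group: chloro in place of hydroxy on an aromatic carbon. A step to a lower number in this assay, beyond the scatter, is expected. Among the measured compounds shown here, the only support is compound 2 at 1900 nM, which also carries no hydroxy, and this is thin evidence. Compound 3 is expected at 2500 nM, with an estimated range of 800 nM to 7000 nM. The expected change is a 4.4-fold lower number from compound 1 to compound 3 (0.64 log units; beyond the scatter).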

Compound 3, half-maximal effective concentration: 2300 nM
For compound 3 the middle estimate is 1.1-fold (0.04 log units) above the measured one; measured number inside the range.
By their numbers in this assay, from the lowest: compounds 2 and 3 (each within the scatter of the next); then compound 1.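

Chloro in place of hydroxy on an aromatic carbon, para to a large group, gives the series its first single-place step: in this assay, the exchange produces a 4.8-fold lower number from compound 1 to compound 3 (0.68 log units; beyond the scatter). The earlier pair differed in more than one place, whereas this step ties a change in the read-out to this position on the shared core. The exchange removes the hydrogen-bond donor and acceptor counted for hydroxy, but no measurement at hand accounts for the step.

The compounds shown leave open whether the step follows from the entry of chloro or from the departure of hydroxy, and a plain hydrogen, methoxy or an amine at this position would help separate the two. Also open, from the compounds shown here alone, is whether the step would persist with a longer chain.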